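Swapping the Amide for an Ester: What to Expect

A few compounds are considered here, and "the series" means these few. Any claim that something is new, unique, unknown or untested is made for them only; others in the source may bear on it.

Measured so far in a functional assay on the whole organism for inhibition, with Brassica rapa subsp. chinensis as the target, with a stated time of 3 days, tested at 100 ppm; on this read-out higher numbers stand for more inhibition of growth at the one concentration tested and lower numbers for less inhibition of growth:
compound 1 `CC(C)NC(=O)/C=C/c1ccccc1`: 39%
compound 2 `CC(C)(C)NC(=O)/C=C/c1ccccc1`: 34%
compound 3 `CCCNC(=O)/C=C/c1ccccc1`: 15%

Compound 3 gives the lowest number of the three. The step of a number 24 percentage points lower from compound 1 to compound 3 (beyond the scatter) and the step of a number 19 percentage points lower from compound 2 to compound 3 (beyond the scatter) both go beyond the scatter, so compound 3 sits clearly under compound 1 and compound 2. The step of a number 5 percentage points lower from compound 1 to compound 2 (within the scatter) is within the scatter, so compound 1 and compound 2 cannot be told apart on these numbers.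

Compound 4 `CCC(C)OC(=O)/C=C/c1ccccc1` has not been measured. It differs from compound 3 in one place: sec-butoxy in place of propylamino on a carbonyl carbon. The group on the carbonyl carbon thus changes from one attached through nitrogen to one attached through oxygen.

Going by the values given here, none of the measured steps touches that point of attachment; all three measured compounds keep an amide-type nitrogen and vary only the group on it. The two steps beyond the scatter, a number 24 percentage points lower from compound 1 to compound 3 (beyond the scatter) and a number 19 percentage points lower from compound 2 to compound 3 (beyond the scatter), concern propyl against isopropyl and tert-butyl on that nitrogen, and give no direct guide for this assay here. The data say nothing about exchanging nitrogen for oxygen. A modest upward step is expected, a number 15 percentage points higher from compound 3 to compound 4 (beyond the scatter), with a wide range. Compound 4 is expected to give 30%, between 5% and 60%.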

Compound 4, percent growth inhibition at one concentration: 18%
Compound 4: the middle estimate sits 12 percentage points above what was measured; measured number inside the range.
By their numbers in this assay, from the lowest: compounds 3 and 4 (each within the scatter of the next); then compounds 2 and 1 (each within the scatter of the next).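

In this assay, putting sec-butoxy in place of propylamino on the carbonyl carbon gives a step within the scatter (a number 3 percentage points higher from compound 3 to compound 4 (within the scatter)), so the two groups cannot be told apart on this read-out, even though sec-butoxy carries no hydrogen-bond donor and propylamino carries one. The branched sec-butoxy group also stays clearly short of the two branched amides, with steps beyond the scatter (a number 16 percentage points lower from compound 2 to compound 4 (beyond the scatter); a number 21 percentage points lower from compound 1 to compound 4 (beyond the scatter)), so the link between a branched chain and the higher numbers, seen so far only on nitrogen, does not hold for compound 4. Nothing at hand explains why this change behaves as it does.

Sec-butoxy and propylamino differ in both the chain and the attaching atom, so the effect of oxygen in place of nitrogen alone remains unresolved. A propoxy group, matched to compound 3, or an isopropoxy group, matched to compound 1, would separate the two, as would a sec-butylamino group from the other side.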